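The source may report more compounds than this note shows. Statements on the series, on what has been measured and on what is new or still open speak of the compounds shown alone.

Measured so far:
Compound 1 `Cc1cc(Nc2ccc(Cl)cc2)nc(SCc2nc3ccccc3[nH]2)n1` gives 36000 nM in a functional assay on PC-3 cells (Homo sapiens) for cytotoxicity, read by MTT assay, with a stated time of 72 h; a lower number here means a stronger inhibitor, a higher number a weaker inhibitor.
Compound 2 `Cc1cc(Nc2ccc(Br)cc2)nc(SCc2nc3ccccc3[nH]2)n1` gives 37100 nM in this assay.

Within the data shown here, compound 2 stands at the higher of the two numbers, but the only measured step between them, a 1.0-fold higher number from compound 1 to compound 2 (0.01 log units; within the scatter), lies within the scatter, so neither compound can be called the stronger inhibitor on these two values. Compound 3 `COc1ccccc1Nc1cc(C)nc(SCc2nc3ccccc3[nH]2)n1` differs from compound 2 in one place: 2-methoxyphenyl in place of 4-bromophenyl on a nitrogen on an aromatic ring. Among the measured compounds shown here, the single measured step is the one from compound 1 to compound 2 already named; it exchanged bromo for chloro on an aromatic carbon and moved the number by nothing beyond the scatter. It bears on compound 3 only loosely, since it says that one change to the group on that nitrogen left the number where it was. For the measured compounds named here, no measured step speaks to a methoxy group or to a 2-substituted phenyl, so the expectation rests on little and carries a wide range. In this assay compound 3 is expected to give 37000 nM, within a range from 12000 nM to 110000 nM. The expected step from compound 2 to compound 3 is a 1.0-fold lower number from compound 2 to compound 3 (0.00 log units; within the scatter), that is, no change beyond the scatter.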

Compound 3, half-maximal inhibitory concentration: 70800 nM
For compound 3 the middle estimate is 1.9-fold (0.28 log units) below the measured one; measured number inside the range.
By their numbers in this assay, from the lowest: compounds 1, 2 and 3 (each within the scatter of the next).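

In this assay, replacing the halogen-bearing ring on the nitrogen with 2-methoxyphenyl gives a 1.9-fold higher number from compound 2 to compound 3 (0.28 log units; within the scatter) and, measured against the chloro analogue, a 2.0-fold higher number from compound 1 to compound 3 (0.29 log units; within the scatter), so neither step can be read as a real difference between the compounds. Among these compounds, the earlier pair showed only that one halogen could be exchanged for another on the same ring, whereas compound 3 loses the halogen altogether and brings in a methoxy group with its oxygen, a hydrogen-bond acceptor, at a different numbered place on the phenyl, and still no step passes beyond the scatter. Nothing available explains this result, and no measurement bears on why the numbers fall as they do.

Since 2-methoxyphenyl differs from 4-bromophenyl in both the substituent and its numbered place, these compounds cannot separate the two changes, and a 4-methoxyphenyl group on the same nitrogen would be needed to do so. From the compounds shown here alone, it also remains open whether a phenyl ring carrying an amine or a carboxylic acid, or a longer chain in place of the phenyl ring, would shift the number beyond the scatter.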